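A few compounds are considered here, and "the series" means these few. Any claim that something is new, unique, unknown or untested is made for them only; others in the source may bear on it.

For the measured compounds named here, in an ADME assay (liver) for metabolic stability, with Liver microsome (Homo sapiens) as the target, using microsomes and NADPH, with a stated time of 30 min, tested at 1 uM (a higher number here means faster removal of the compound, a lower number slower removal), compound 2 `CC(C)(C)n1cc(-c2cc(C(O)(C(F)(F)F)C(F)(F)F)cnc2N2CCN(S(=O)(=O)c3ccc(N)nc3)CC2)cn1` gives 86 mL.min-1.g-1, the only actual number so far. Compound 1 `Nc1ccc(S(=O)(=O)N2CCN(c3ncc(C(O)(C(F)(F)F)C(F)(F)F)cc3C#CCCO)CC2)cn1` gives < 14 mL.min-1.g-1, which is a limit of the assay. Going by the values given here, the one measured step is an at least 6.1-fold higher number from compound 1 to compound 2 (0.78 log units; beyond the scatter), where 1-(tert-butyl)-1H-pyrazol-4-yl takes the place of 4-hydroxybut-1-yn-1-yl. Compound 3 `Cc1csc(-c2cc(C(O)(C(F)(F)F)C(F)(F)F)cnc2N2CCN(S(=O)(=O)c3ccc(N)nc3)CC2)c1` instead carries 4-methylthiophen-2-yl in place of that 1-(tert-butyl)-1H-pyrazol-4-yl (4-methylthiophen-2-yl in place of 1-(tert-butyl)-1H-pyrazol-4-yl on an aromatic carbon). That measured step does not involve the entering group, so it offers only loose guidance. Compound 3 is expected to stay near compound 2 at 86 mL.min-1.g-1, with an estimated step of a 1.4-fold lower number from compound 2 to compound 3 (0.16 log units; within the scatter). For compound 3 the estimate is 60 mL.min-1.g-1, with an expected range of 25 mL.min-1.g-1 to 140 mL.min-1.g-1.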

Compound 3, intrinsic clearance in microsomes: 29 mL.min-1.g-1
The estimate for compound 3 lay 2.1-fold (0.32 log units) above the measured number; measured number inside the range.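

In this assay, the aromatic carbon two atoms from the ring nitrogen proves sensitive to which five-membered aromatic ring it carries, not only to the loss of 4-hydroxybut-1-yn-1-yl: the swap to 4-methylthiophen-2-yl gives a 3.0-fold lower number from compound 2 to compound 3 (0.47 log units; beyond the scatter). The 4-methylthiophen-2-yl group still does not return to the level of 4-hydroxybut-1-yn-1-yl, with an at least 2.0-fold higher number from compound 1 to compound 3 (0.31 log units; beyond the scatter). The value of compound 1 is a limit of the assay, not a number: the limit of < 14 mL.min-1.g-1 in this assay, at which 1 of the 3 values shown sits.

Going by these compounds, the swap changes the ring and its substituent together, so the share of the tert-butyl group, the methyl group and the sulfur atom stays open. Also open, on these data alone, is how a thiophene without the methyl group, or an amine at the end of the butynyl chain, would behave here.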